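The source may hold more compounds than are shown below. What is called first, only, known or untested is meant among the compounds shown, and "the series" means these compounds.

Measured in an ADME assay on LLC-MK2 cells (Macaca mulatta) for cytotoxicity, read by spectrophotometry and crystal violet staining, with a stated time of 4 days; on this read-out higher numbers stand for lower toxicity in this test and lower numbers for higher toxicity in this test:
- Compound 1 `CC(C)n1ccc2c(C(=O)Nc3ccccn3)cc(-c3cccs3)nc21`: > 200000 nM
- Compound 2 `CC(C)n1ncc2c(C(=O)N3CCc4cccnc43)cc(-c3cccs3)nc21`: 50000 nM
- Compound 3 `CC(C)n1ncc2c(C(=O)Nc3ccc(F)cc3)cc(-c3ccco3)nc21`: > 200000 nM

Compound 1 stands at > 200000 nM, which is a limit of the assay and not a number. This is the same limit reached by most of the series (the limit of > 200000 nM in this assay, at which 2 of the 3 values shown sit). Within the data shown here, compound 2 is the only one with an exact number, 50000 nM.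

Compound 4 `CC(C)n1ccc2c(C(=O)Nc3ccc(F)cc3)cc(-c3cccs3)nc21` keeps the core of compound 1 but carries 4-fluorophenyl in place of pyridin-2-yl on an amide-type nitrogen. Among the measured compounds shown here, no measured pair shows this change alone. Compound 3 also carries 4-fluorophenyl there and reads > 200000 nM, again a limit. In this assay the expected step of an at least 1.1-fold lower number from compound 1 to compound 4 (0.04 log units; that floor lies within the scatter) is therefore none beyond the scatter. For compound 4 the estimated value is 180000 nM, with an expected range of 70000 nM to 300000 nM.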

Compound 4, half-maximal cytotoxic concentration: > 200000 nM
Compound 4 gave a limit, no number; the forecaster's own chance of this, stated with the estimate: 65%; middle value at least 1.1-fold (0.04 log units) from the limit.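

Compound 1 and compound 4 both end at a limit of the assay, so no step can be read between them. Still open, on these data alone, is whether 4-fluorophenyl in place of pyridin-2-yl changes the result in this assay at all.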